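Nitro to acetyl at the cytotoxicity limit

The source may report more compounds than this note shows. Statements on the series, on what has been measured and on what is new or still open speak of the compounds shown alone.

In an ADME assay on MDBK cells (Bos taurus) for cytotoxicity, read by MTT assay, with a stated time of 96 h (a higher number here means that more compound is tolerated, a lower number that less compound is tolerated), compound 2 (`COc1ccc(-c2nc3cc([N+](=O)[O-])ccc3[nH]2)c(OC)c1`) stands at > 100000 nM as a limit of the assay, not a number. Compound 1 (`COc1ccc(-c2nc3cc(C(F)(F)F)ccc3[nH]2)c(OC)c1`) stands at > 100000 nM as a limit too. Among the compounds with values here, the one measured change is a step that the two limits leave unreadable from compound 1 to compound 2 and gives no size to carry over. Within the data shown here, the series so far offers the limit of > 100000 nM in this assay, at which 2 of the 2 values shown sit, as its only anchor. Compound 3 (`COc1ccc(-c2nc3cc(C(C)=O)ccc3[nH]2)c(OC)c1`) has acetyl in place of nitro on an aromatic carbon. The expectation leans on compound 2 and its limit of > 100000 nM alone. No step beyond the scatter is expected, and the estimated change (a number no higher from compound 2 to compound 3 (the limit leaves the size open)) will probably be reported as a limit again. Compound 3 is expected at 100000 nM within a range of 40000 nM to 200000 nM in this assay as well.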

Compound 3, half-maximal cytotoxic concentration: > 100000 nM
Compound 3: a limit, no number; the forecaster's own chance of this, stated with the estimate: 80%; the middle value sits exactly at the limit.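

Within the data shown here, compound 1, compound 2 and compound 3 all stand at a limit, not a number, in this assay, so no step among them can be read. The compounds shown leave open whether trifluoromethyl, nitro and acetyl differ at all in this assay.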